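Swapping the Aryl Group on a Hydrazone Urea

A few compounds are considered here, and "the series" means these few. Any claim that something is new, unique, unknown or untested is made for them only; others in the source may bear on it.

compound 1 `CN(C)CCn1cnnc1-c1cc(Oc2ccc(NC(=O)N/N=C/c3c[nH]c4ccccc34)cc2F)ccn1` gives 690 nM in a functional assay on U-87MG ATCC cells (Homo sapiens) for cytotoxicity, read by MTT assay, with a stated time of 72 h; on this read-out lower numbers stand for stronger inhibition and higher numbers for weaker inhibition
compound 2 `COc1cc(/C=N/NC(=O)Nc2ccc(Oc3ccnc(-c4nncn4CCN(C)C)c3)c(F)c2)cc(OC)c1OC` gives 22500 nM
compound 3 `CN(C)CCn1cnnc1-c1cc(Oc2ccc(NC(=O)N/N=C/c3cccc(Cl)c3Cl)cc2F)ccn1` gives 13200 nM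

In this assay compound 3 stands second highest of the three numbers: compound 2 lies within the scatter of it, whereas compound 1 lies far lower. The change to compound 4 `CN(C)CCn1cnnc1-c1cc(Oc2ccc(NC(=O)N/N=C/c3ccc(O)cc3)cc2F)ccn1` is 4-hydroxyphenyl in place of 2,3-dichlorophenyl on a carbon with a double bond to nitrogen. Earlier steps at this same place were large in two cases, a 33-fold higher number from compound 1 to compound 2 (1.51 log units; beyond the scatter) and a 19-fold higher number from compound 1 to compound 3 (1.28 log units; beyond the scatter), while a 1.7-fold lower number from compound 2 to compound 3 (0.23 log units; within the scatter). Within the data shown here, the group at this position can therefore move the number strongly, but no measured step shows what a 4-hydroxyphenyl does there, so the direction is open. Compound 4 is expected near 6000 nM, with a range of 1500 nM to 25000 nM. That estimate means a 2.2-fold lower number from compound 3 to compound 4 (0.34 log units; beyond the scatter), an expected change that stays uncertain.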

Compound 4, half-maximal inhibitory concentration: 7750 nM
For compound 4 the middle estimate is 1.3-fold (0.11 log units) below the measured one, within the range that was stated.
By their numbers in this assay, from the lowest: compound 1; then compounds 4, 3 and 2 (each within the scatter of the next, the first and the last beyond it).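

In this assay, an 11-fold higher number from compound 1 to compound 4 (1.05 log units; beyond the scatter) shows that a phenyl group carrying a hydroxyl does not match the 1H-indol-3-yl group. Beside that large gap, a 1.7-fold lower number from compound 3 to compound 4 (0.23 log units; within the scatter) separates the 4-hydroxyphenyl and 2,3-dichlorophenyl groups, while a 2.9-fold lower number from compound 2 to compound 4 (0.46 log units; beyond the scatter) shows a modest difference from the 3,4,5-trimethoxyphenyl group. Nothing available explains these differences.

The compounds shown leave open whether the low number of compound 1 is special to 1H-indol-3-yl. A naphthyl or quinolinyl group on this carbon would test that.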